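Acetamido in Place of Methoxy: Estimating Compound 4

A few compounds are considered here, and "the series" means these few. Any claim that something is new, unique, unknown or untested is made for them only; others in the source may bear on it.

Compound 1 `COc1ccc(S(=O)(=O)NCCN2CCC(CCC(=O)c3cc(Cl)c(N)cc3OC)CC2)cc1` — 12.3 nM
Compound 2 `COc1ccc(S(=O)(=O)CCCN2CCC(CCC(=O)c3cc(Cl)c(N)cc3OC)CC2)cc1` — 12.2 nM
Compound 3 `COc1ccc(S(=O)(=O)NCCCN2CCC(CCC(=O)c3cc(Cl)c(N)cc3OC)CC2)cc1` — 26 nM

Of the compounds shown here, three sharing one core have been measured in an assay on brain for displacement of a labelled ligand from 5-hydroxytryptamine receptor 4 (Cavia porcellus), with a stated time of 30 min, in the presence of a further agent that is not named here; a lower number here means a stronger inhibitor, a higher number a weaker inhibitor. Compound 1 gives 12.3 nM, the second highest of the three numbers. Compound 2 gives 12.2 nM, which lies within the scatter of compound 1, so the two cannot be told apart. Going by the values given here, compound 3 gives 26 nM, a higher number than compound 1 and a gap beyond the scatter; no single-site step between these compounds is recorded, so only the two values themselves can be compared.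

Compound 4 `COc1cc(N)c(Cl)cc1C(=O)CCC1CCN(CCNS(=O)(=O)c2ccc(NC(C)=O)cc2)CC1` is unmeasured. It differs from compound 1 in one place: acetamido in place of methoxy on an aromatic carbon. No measured pair shows this change, so the size of the step has no direct precedent among these compounds. The expectation is a small step, most likely toward a somewhat higher number in this assay, though a result within the scatter of compound 1 would not surprise. The step from compound 1 to compound 4 is estimated at a 1.8-fold higher number from compound 1 to compound 4 (0.25 log units; within the scatter). Compound 4 is therefore estimated at 22 nM, with a range from 7 nM to 70 nM.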

Compound 4, inhibition constant: 7.7 nM
Beside the measured number, compound 4's estimate is 2.9-fold (0.46 log units) above it; the measured number falls inside the stated range.
By their numbers in this assay, from the lowest: compounds 4, 2 and 1 (each within the scatter of the next); then compound 3.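

In this assay the change from 4-methoxyphenyl to 4-acetamidophenyl gives a 1.6-fold lower number from compound 1 to compound 4 (0.20 log units; within the scatter) and so leaves compound 1 and compound 4 indistinguishable. Going by these compounds alone, this is the first view of this position, on an aromatic carbon para to a large group, since the earlier compounds all carry methoxy there and differ only elsewhere: acetamido brings 4 heavy atoms where methoxy has 2, and 1 hydrogen-bond donor where methoxy has none, yet the step stays within the scatter, so on this core the larger group is accommodated at this place with no measurable loss or gain. No measurement given here offers any account of why the step has this size.

From the compounds shown here alone, whether an amine, a carboxylic acid or a longer acyl chain at this position would also stay within the scatter of compound 1 remains open, and a single pair cannot show how far the position accepts other groups. Going by these compounds, it is also open whether acetamido in place of methoxy gives a step of like size on the cores of compound 2 and compound 3.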